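Chloro in place of hydrogen on compound 3

The compounds below may be only part of what the source reports. "The series", "measured", "known", "first", "only" and "open" are said of these compounds alone.

Measured in a functional assay on MGC-803 cells (Homo sapiens) for inhibition, read by sulforhodamine B assay; on this read-out lower numbers stand for stronger inhibition and higher numbers for weaker inhibition:
compound 1 `O=C1C=C(N2CCC2)C(=O)c2c1nc1n2[C@H]2OC[C@@H](O)[C@H]2OC1`: > 16000 nM
compound 2 `COc1ccccc1NC1=CC(=O)c2nc3n(c2C1=O)[C@H]1OC[C@@H](O)[C@H]1OC3`: 1630 nM
compound 3 `O=C1C=C(Nc2ccccc2)C(=O)c2c1nc1n2[C@H]2OC[C@@H](O)[C@H]2OC1`: 1730 nM

Compound 1 has the entry > 16000 nM, which is a limit of the assay and not a number. Compound 3, at 1730 nM, stands level with compound 2, since a 1.1-fold higher number from compound 2 to compound 3 (0.03 log units; within the scatter). Replacing the azetidin-1-yl group with anilino gives a far larger difference, an at least 9.2-fold lower number from compound 1 to compound 3 (0.96 log units; beyond the scatter).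

The next compound is compound 4 `O=C1C=C(Nc2cccc(Cl)c2)C(=O)c2c1nc1n2[C@H]2OC[C@@H](O)[C@H]2OC1`. It differs from compound 3 by chloro in place of hydrogen on an aromatic carbon, which is chloro in place of hydrogen on an aromatic carbon, meta to a large group. Going by the values given here, the nearest evidence is the one measured step that changes a substituent on this aromatic ring, hydrogen in place of methoxy, and there a 1.1-fold higher number from compound 2 to compound 3 (0.03 log units; within the scatter). The step from compound 1 exchanges the whole amine and says little about a single substituent. Among the compounds with values here, no measured compound carries chloro, so the estimate rests on that one small step, and no change beyond the scatter is expected in this assay. The expected step is a 1.3-fold lower number from compound 3 to compound 4 (0.12 log units; within the scatter). For compound 4 the estimated value is 1300 nM, with an expected range from 450 nM to 4000 nM.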

Compound 4, half-maximal inhibitory concentration: 1770 nM
Compound 4: the middle estimate sits 1.4-fold (0.13 log units) below what was measured; the range from low to high includes it.
By their numbers in this assay, from the lowest: compounds 2, 3 and 4 (each within the scatter of the next). At a limit, above all of these: compound 1.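

In this assay, chloro in place of hydrogen on this aromatic carbon, meta to a large group, leaves the read-out level, a 1.0-fold higher number from compound 3 to compound 4 (0.01 log units; within the scatter), so this place on the ring takes one chlorine atom with no change beyond the scatter. The earlier compounds shown here showed only the loss of methoxy from the anilino ring, and the exchange of 3-chlorophenyl for 2-methoxyphenyl on the amine nitrogen now also stays within the scatter, a 1.1-fold higher number from compound 2 to compound 4 (0.04 log units; within the scatter), which leaves compound 2, compound 3 and compound 4 level. The exchange of the whole amine remains much the larger difference, an at least 9.0-fold lower number from compound 1 to compound 4 (0.95 log units; beyond the scatter), and that step is only a bound, since the entry for compound 1 is a limit and not a number: the limit of > 16000 nM in this assay, at which 1 of the 4 values shown sits.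

Going by these compounds, whether a basic amine or a carboxylic acid at this ring carbon would shift the read-out beyond the scatter remains open. So does the effect of replacing the anilino group with a longer alkyl chain on the amine nitrogen, since the only non-aryl amine shown is the azetidin-1-yl group.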